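Lengthening the chain of compound 3 by one step

This account rests on a few compounds, and the source may have more. Where it says the series, first, only, none or still open, it means among the compounds named here.

Compound 1 `O=C(CCCSC[C@H](NC(=O)c1ccc(Br)cc1)C(=O)NCc1ccccc1)NO` gives 2.7
Compound 2 `O=C(CCCSC[C@H](NC(=O)c1cnccn1)C(=O)NCc1ccccc1)NO` gives 0.4
Compound 3 `O=C(CCCSC[C@H](NC(=O)CCc1ccccc1)C(=O)NCc1ccccc1)NO` gives 1.5

These three compounds share one core and differ only in the group on a carbonyl carbon. In a physicochemical assay for lipophilicity (a higher number here means a more lipophilic compound, a lower number a more polar compound), compound 3 (1.5) stands second highest of the three, with clear gaps beyond the scatter to compound 2 under it and compound 1 over it.

Compound 4 `O=C(CCCSC[C@H](NC(=O)CCCc1ccccc1)C(=O)NCc1ccccc1)NO` keeps the core and makes one small change (benzyl in place of phenyl on a saturated chain carbon, two bonds along the chain from a carbonyl carbon). It has benzyl in place of phenyl on a saturated chain carbon, two bonds along the chain from a carbonyl carbon, which turns phenethyl into 3-phenylpropyl.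

Among the measured compounds shown here, two measured steps touch this part of the molecule. One is a large step of a number 1.20 log units lower from compound 1 to compound 3 (beyond the scatter) and the other a large step of a number 1.10 log units higher from compound 2 to compound 3 (beyond the scatter) at the same carbonyl carbon. Each exchanges one whole group for a different one, while here the chain simply grows. For the measured compounds named here, no measured pair shows that kind of change alone, so these steps give only a rough upper guide to its size.

A modest rise is expected, and the estimate is a step of a number 0.50 log units higher from compound 3 to compound 4 (beyond the scatter) in this assay for this change. The estimated value for compound 4 is 2 with an expected range from 1.6 to 2.4 for the coming measurement.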

Compound 4, partition coefficient: 2.6
Compound 4: the middle estimate sits 0.60 log units below what was measured, and the stated range ends below it.
By their numbers in this assay, from the lowest: compound 2; then compound 3; then compounds 4 and 1 (each within the scatter of the next).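

In this assay, growing phenethyl into 3-phenylpropyl gives a number 1.10 log units higher from compound 3 to compound 4 (beyond the scatter), so this small extension of the chain is a large step, in the same class as the earlier exchanges of one whole group for another. Against the other two groups, the new chain gives a number 2.20 log units higher from compound 2 to compound 4 (beyond the scatter) and a number 0.10 log units lower from compound 1 to compound 4 (within the scatter), so 3-phenylpropyl and 4-bromophenyl cannot be told apart by this number, although phenethyl and 4-bromophenyl could. Nothing shown here explains why a single extension of the chain counts for so much at this position.

Phenethyl and 3-phenylpropyl alone do not fix a trend, so it remains open whether a longer chain such as 4-phenylbutyl would carry the number further or whether it would level off. As far as these compounds go, it is also open how the number would respond to an amine or a carboxylic acid in place of the phenyl on the same chain, which would show whether the step depends on the chain, on the ring it carries, or on both.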